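The source may report more compounds than this note shows. Statements on the series, on what has been measured and on what is new or still open speak of the compounds shown alone.

Measured compounds:
compound 1 `CCn1c(=O)[nH]c2ccc(OCCOc3ccc(OC)cc3)cc21` — 13.9%
compound 2 `Cn1c(=O)[nH]c2ccc(OCc3cccc(F)c3)cc21` — 5.36%
compound 3 `O=C1Nc2ccc(OCc3ccc(F)cc3)cc2C1=O` — 92.5%

All three were tested in an assay on cells for inhibition of Amine oxidase [flavin-containing] B (Homo sapiens), read by fluorescence, with stated times of 30 min and 15 min, tested at 1 uM; on this read-out higher numbers stand for more inhibition at the one concentration tested (going by the name of the read-out) and lower numbers for less inhibition. Compound 1 gives 13.9% in this assay, the second highest of the three numbers. Compound 2 gives 5.36%, a number that sits within the usual scatter of compound 1, so the two cannot be told apart. Among the measured compounds shown here, compound 3 gives 92.5%, far higher than compound 1 and well beyond the scatter; no single-point step connects it to compound 1, as the two differ in more than one place, so only the two values themselves can be set side by side.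

Compound 4 `COc1ccc(OCCOc2ccc3[nH]c(=O)n(C(C)C)c3c2)cc1` has not yet been measured. It differs from compound 1 in one place: methyl in place of hydrogen on a saturated chain carbon bound to an aromatic nitrogen and a saturated chain carbon. For the measured compounds named here, no pair among the measured compounds differs in just one place, so there is no measured step of this kind to lean on. A change as small as one added carbon on the saturated chain carbon bound to the aromatic nitrogen is expected to leave the result about where compound 1 stands, with no step beyond the scatter in either direction. Compound 4 is therefore estimated at 15%, with a range from 3% to 35%. The expected step from compound 1 to compound 4 is a number 1.1 percentage points higher from compound 1 to compound 4 (within the scatter), that is, essentially none.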

Compound 4, a percentage reported as inhibition, at one concentration (the size of the read-out at that concentration, not a potency): 15.5%
For compound 4 the middle estimate is 0.5 percentage points below the measured one; low and high end bracket the measured number.
By their numbers in this assay, from the lowest: compounds 2, 1 and 4 (each within the scatter of the next, the first and the last beyond it); then compound 3.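

Among the compounds shown here, this is the first comparison in the set in which only one place changes: ethyl becomes isopropyl, with methyl in place of hydrogen on a saturated chain carbon bound to an aromatic nitrogen and a saturated chain carbon, and in this assay this gives a number 1.6 percentage points higher from compound 1 to compound 4 (within the scatter) as the step. This position therefore takes one added carbon with no change that can be told apart from ordinary scatter, at least with the side chain shared by these two compounds and at the one concentration tested. No measurement here bears on why the step is so small.

As far as these compounds go, a single small step says little about how much room this position offers, so it stays open whether a bulkier tert-butyl, a longer chain such as butyl, or a chain ending in an amine or a carboxylic acid would move the number beyond the scatter. From the compounds shown here alone, it also stays open whether ethyl and isopropyl would still match on a compound with a different side chain on the shared core.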